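A few compounds are considered here, and "the series" means these few. Any claim that something is new, unique, unknown or untested is made for them only; others in the source may bear on it.

Measured so far in an ADME assay on HEL cells (Homo sapiens) for cytotoxicity, read by microscopy; a lower number here means that less compound is tolerated, a higher number that more compound is tolerated:
Compound 1 `O=c1ccn(CCCCCOc2ccc(Br)cc2)c(=O)[nH]1` gives 100000 nM in this assay.
Compound 2 `Nc1ccc(OCCCCCn2ccc(=O)[nH]c2=O)cc1` gives only a limit of the assay, > 100000 nM, not a number.
Compound 3 `Cc1ccccc1OCCCCCn1ccc(=O)[nH]c1=O` likewise gives only a limit of the assay, > 100000 nM.

Among the compounds with values here, compound 1 stands as the only compound with a number in this assay; the other two values are limits, so no order among the three can be read. Compound 4 `O=c1ccn(CCCCCOc2ccccc2)c(=O)[nH]1` is not yet measured. It differs from compound 1 by hydrogen in place of bromo on an aromatic carbon. Two measured steps start from compound 1 and bear on this change: a number no lower from compound 1 to compound 2 (the limit leaves the size open) and a number no lower from compound 1 to compound 3 (the limit leaves the size open). Neither has a readable size because of the limit of > 100000 nM in this assay, at which 2 of the 3 values shown sit. Both alter the bromo-bearing ring without lowering the number. For compound 4 the expected step is therefore no change at the digits printed from compound 1 to compound 4 (within the scatter), with no drop beyond the scatter and most likely again a limit rather than a number. Compound 4 is estimated at 100000 nM, in the range 50000 nM to 200000 nM.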

Compound 4, minimum cytotoxic concentration: > 100000 nM
Compound 4 was reported as a limit; the forecaster's own chance of this, stated with the estimate: 60%; the middle value sits exactly at the limit.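

With hydrogen in place of bromo on the aromatic carbon para to a large group, the phenyl ring carries no substituent, and this assay shows a number no lower from compound 1 to compound 4 (the limit leaves the size open), so no substituent at this position is needed to keep the number from falling. Compound 4 gives > 100000 nM, which is a limit of the assay and not a number. The steps linking compound 4 to compound 2 and compound 3 cannot be read, and the size of the change from bromo to hydrogen stays open because of the shared ceiling: the limit of > 100000 nM in this assay, at which 3 of the 4 values shown sit.

Within the data shown here, compound 1 remains the only compound with a number, so no ranking of ring substituents is possible. On these data alone, it remains open whether a carboxylic acid on the phenyl ring or a longer chain to the shared core would lower the number in this assay.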